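Chloro for methoxy on the six-membered ring of compound 3

This account rests on a few compounds, and the source may have more. Where it says the series, first, only, none or still open, it means among the compounds named here.

Compound 1 `Cc1noc(-c2cc3ccccc3[nH]2)n1` in a functional assay on MCF7 cells (Homo sapiens) for antiproliferative activity, read by WST assay, with a stated time of 72 h (on this read-out lower numbers stand for stronger inhibition and higher numbers for weaker inhibition), gives > 50000 nM, a limit of the assay rather than a number. Compound 2 `COc1ccc2[nH]c(-c3nc(C)no3)cc2c1` carries a methoxy group and in this assay gives 16700 nM; the step is an at least 2.9-fold lower number from compound 1 to compound 2 (0.47 log units; beyond the scatter). Compound 3 `COc1ccc2[nH]c(-c3nc(-c4ccccc4)no3)cc2c1` carries a phenyl in place of the methyl, and in this assay compound 3 gives > 50000 nM, again a limit and not a number. The step of an at least 2.9-fold higher number from compound 2 to compound 3 (0.47 log units; beyond the scatter) runs back to the limit. On the numbers shown, compound 3 stands at the limit of > 50000 nM in this assay, at which 2 of the 3 values shown sit, together with compound 1, and compound 2 alone gives a number.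

Compound 4 `Clc1ccc2[nH]c(-c3nc(-c4ccccc4)no3)cc2c1` differs from compound 3 by chloro in place of methoxy on an aromatic carbon. Neither measured step concerns an exchange of methoxy for chloro: one adds methoxy to hydrogen, the other puts phenyl in place of methyl, each at least modest in size. Nothing shown therefore argues for a step beyond the scatter in this assay, and with compound 3 already at the limit, compound 4 is expected to be reported there as well. The expected step is a number no higher from compound 3 to compound 4 (the limit leaves the size open). Compound 4 is estimated at 50000 nM, with a range from 20000 nM to 150000 nM.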

Compound 4, half-maximal inhibitory concentration: 29100 nM
Beside the measured number, compound 4's estimate is 1.7-fold (0.24 log units) above it; measured number inside the range.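

Chloro in place of methoxy is the first exchange shown in which one substituent replaces another on this aromatic carbon of the six-membered ring, whereas the earlier step at this carbon put methoxy in place of hydrogen, and in this assay it reads as an at least 1.7-fold lower number from compound 3 to compound 4 (0.23 log units; that floor lies within the scatter). With the phenyl group held constant, compound 4 returns a measurable number, so a methoxy group is not required at this carbon for a number to be obtained, although the floor of the step does not separate the pair from the usual scatter. The value of compound 3 is a limit and not a number, which leaves only a floor for the step, and the series reads as follows: the limit of > 50000 nM in this assay, at which 2 of the 4 values shown sit.

As far as these compounds go, whether chloro in place of methoxy would move the read-out in the same direction with the methyl group of compound 2 instead of the phenyl stays open, as does the true size of the step. Also open, from the compounds shown here alone, is how an amine, a carboxylic acid or a longer alkoxy chain such as ethoxy on this carbon would read in this assay.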